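A few compounds are considered here, and "the series" means these few. Any claim that something is new, unique, unknown or untested is made for them only; others in the source may bear on it.

In a functional assay on 786-0 cells (Homo sapiens) for inhibition, read by sulforhodamine B assay, with a stated time of 48 h (a lower number here means a stronger inhibitor of growth, a higher number a weaker inhibitor of growth), the compounds shown here spread over a wide stretch. Compound 1 `COc1cc(OC)c(OC)cc1/C=C/C1CC=CC(=O)O1` gives 6 uM. Compound 2 `O=C1C=CCC(/C=C/c2ccccc2)N1` is the unsubstituted parent of the lactam pair. For compound 2 the assay reports only its limit, > 1250 uM, so no number is known for it. That limit is the limit of > 1250 uM in this assay, at which 1 of the 3 values shown sits. Compound 3 `O=C1C=CCC(/C=C/c2ccccc2C(F)(F)F)N1` gives 123 uM, which corresponds to an at least 10-fold lower number from compound 2 to compound 3 (1.00 log units; beyond the scatter).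

Compound 4 `COc1ccc(/C=C/C2CC=CC(=O)N2)cc1` has not yet been measured in this assay. It differs from compound 2 in one place: methoxy in place of hydrogen on an aromatic carbon. Among the measured compounds shown here, only one measured step bears on this change, the one with the trifluoromethyl group, an at least 10-fold lower number from compound 2 to compound 3 (1.00 log units; beyond the scatter), which shows that a single substituent on that aromatic ring can move the lactam core off its limit. For the measured compounds named here, compound 1 carries methoxy groups but on another core, and no step connects it to the lactams, so it shows only that methoxy-bearing compounds can reach low numbers in this assay.

A lowering is therefore expected for compound 4, though a methoxy is a different group from trifluoromethyl, so the expected step is an at least 3.1-fold lower number from compound 2 to compound 4 (0.49 log units; beyond the scatter). Compound 4 is estimated to give about 400 uM, within a range from 80 uM to 1250 uM.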

Compound 4, concentration for growth inhibition (reported as GI): > 1090 uM
Compound 4: a limit, no number (the forecaster's own chance of this, stated with the estimate: 40%); middle value at least 2.7-fold (0.43 log units) away from the limit.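

In this assay compound 4 gives only a limit, > 1090 uM. Among the compounds shown here, compound 2 also gives only a limit, > 1250 uM, so no step between compound 2 and compound 4 can be read. The compounds shown leave open whether methoxy in place of hydrogen on an aromatic carbon changes growth inhibition on the shared core at all.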